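The source may report more compounds than this note shows. Statements on the series, on what has been measured and on what is new or still open speak of the compounds shown alone.

Measured so far:
Compound 1 `CCS(=O)(=O)Nc1ccc(CNC(=O)c2ccc(C(C)(C)C)cc2)c(Cl)c1` gives 28 mL.min-1.g-1 in an ADME assay on microsomes from liver (Rattus norvegicus, strain Sprague-Dawley) for metabolic stability, read by HPLC, using NADPH, with stated times of 5 min and 60 min, tested at 10 uM; on this read-out higher numbers stand for fast clearance and lower numbers for slow clearance.
Compound 2 `CS(=O)(=O)Nc1ccc(CNC(=O)c2ccc(N3CCCC3)cc2)c(Cl)c1` gives 17 mL.min-1.g-1 in this assay.

On these two numbers compound 2 stands lowest, with compound 1 the nearest, within the scatter. Compound 3 `CS(=O)(=O)Nc1ccc(CNC(=O)c2ccc(S(F)(F)(F)(F)F)cc2)c(Cl)c1` is not yet measured. It differs from compound 2 in one place: a group of 6 heavy atoms (5 fluorine, 1 sulfur; no ring) in place of a group of 5 heavy atoms (4 carbon, 1 nitrogen; one five-membered non-aromatic ring with 1 hetero atom), on an aromatic carbon. Among the compounds with values here, no step between two measured compounds is known for a change of this kind, so nothing in the data points one way or the other. The expectation for compound 3 is therefore no step beyond the scatter, a 1.2-fold higher number from compound 2 to compound 3 (0.07 log units; within the scatter). Compound 3 is expected to give 20 mL.min-1.g-1, with a range from 8 mL.min-1.g-1 to 45 mL.min-1.g-1.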

Compound 3, intrinsic clearance in microsomes: 9.8 mL.min-1.g-1
Compound 3: middle estimate off by 2.0-fold (0.31 log units), on the high side; low and high end bracket the measured number.
By their numbers in this assay, from the lowest: compounds 3, 2 and 1 (each within the scatter of the next, the first and the last beyond it).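

In this assay, within the data shown here, the first readable step on an aromatic carbon para to a large group is a 1.7-fold lower number from compound 2 to compound 3 (0.24 log units; within the scatter). At this place, therefore, pyrrolidin-1-yl and the ringless group of five fluorine atoms on sulfur cannot be told apart by their clearance numbers, despite their different atoms and the loss of the ring. No measurement shown bears on the reason for this. As far as these compounds go, whether a carboxylic acid or an open-chain amine such as dimethylamino at this place would give a step beyond the scatter remains open. So does whether this exchange would read the same with the ethylsulfonyl group of compound 1 in place of the methylsulfonyl group.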